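The source may report more compounds than this note shows. Statements on the series, on what has been measured and on what is new or still open speak of the compounds shown alone.

Three compounds share one core and differ only in the group attached to the carbonyl carbon of the amide. Compound 1 `COc1cc(-c2nn(-c3cccc(NC(=O)Nc4ccc(Cl)c(Cl)c4)c3)cc2-c2ccncc2)ccc1Cl` gives 1410 nM in a functional assay on NCI-H23 cells (Homo sapiens) for inhibition, read by sulforhodamine B assay, with a stated time of 48 h (a lower number here means a stronger inhibitor of growth, a higher number a weaker inhibitor of growth), compound 2 `COc1cc(-c2nn(-c3cccc(NC(=O)c4ccc(Cl)c(C(F)(F)F)c4)c3)cc2-c2ccncc2)ccc1Cl` gives 5390 nM, and compound 3 `COc1cc(-c2nn(-c3cccc(NC(=O)Nc4ccc(Cl)c(C(F)(F)F)c4)c3)cc2-c2ccncc2)ccc1Cl` gives 1310 nM, the lowest of the three, though only by a step that is a 1.1-fold lower number from compound 1 to compound 3 (0.03 log units; within the scatter). Compound 4 `COc1cc(-c2nn(-c3cccc(NC(=O)c4ccccc4)c3)cc2-c2ccncc2)ccc1Cl` has not yet been measured; it differs from compound 3 by phenyl in place of (4-chloro-3-(trifluoromethyl)phenyl)amino on a carbonyl carbon. The step of a 4.1-fold lower number from compound 2 to compound 3 (0.61 log units; beyond the scatter) bears on this change, since compound 4 reverses it and also loses both chloro and trifluoromethyl. Compound 4 is therefore expected to give a higher number, estimated at 8000 nM (range 3000 nM to 25000 nM), a step of a 6.1-fold higher number from compound 3 to compound 4 (0.79 log units; beyond the scatter).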

Compound 4, concentration for 50% growth inhibition: 2020 nM
Beside the measured number, compound 4's estimate is 4.0-fold (0.60 log units) above it, outside the stated range (below it).
By their numbers in this assay, from the lowest: compounds 3, 1 and 4 (each within the scatter of the next); then compound 2.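

Swapping the whole (4-chloro-3-(trifluoromethyl)phenyl)amino group for plain phenyl on the carbonyl carbon stays within the scatter, with a 1.5-fold higher number from compound 3 to compound 4 (0.19 log units; within the scatter) and, for the (3,4-dichlorophenyl)amino group, a 1.4-fold higher number from compound 1 to compound 4 (0.16 log units; within the scatter). Among the two compounds with a ring directly on the carbonyl carbon, however, the chloro and trifluoromethyl groups go with the higher number, as a 2.7-fold lower number from compound 2 to compound 4 (0.43 log units; beyond the scatter) shows. No measured evidence here explains these steps. Still open, on these data alone, is whether chloro or trifluoromethyl alone accounts for that step, and whether an unsubstituted phenylamino group, an amine or a carboxylic acid on the phenyl would move the number.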